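The source may report more compounds than this note shows. Statements on the series, on what has been measured and on what is new or still open speak of the compounds shown alone.

Measured so far in an ADME assay on microsomes from liver (Mus musculus) for metabolic stability, read by LC-MS, with a stated time of 10 min (on this read-out higher numbers stand for a more stable compound and lower numbers for a less stable compound), are:
- compound 1 `CC(C)N1CCN(c2cccc3c2C[C@H](CN(C)[C@H]2CCCc4cccnc42)NC3)CC1` with 15.1% remaining
- compound 2 `FC1(F)CCC(CN(C[C@H]2Cc3c(cccc3N3CCNCC3)CN2)[C@H]2CCCc3cccnc32)CC1` with 76.6% remaining
- compound 3 `CC(C)N(C[C@H]1Cc2c(cccc2N2CCNCC2)CN1)[C@H]1CCCc2cccnc21` with 91% remaining

Compound 1 holds the lowest of these three numbers, far under the other two. Compound 4 `CCN1CCN(c2cccc3c2C[C@H](CN(C)[C@H]2CCCc4cccnc42)NC3)CC1` is still unmeasured. It differs from compound 1 by one small edit (hydrogen in place of methyl on a saturated chain carbon bound to an amine nitrogen in a ring and a saturated chain carbon), hydrogen in place of methyl on a saturated chain carbon bound to an amine nitrogen in a ring and a saturated chain carbon, turning isopropyl into ethyl. Going by the values given here, the one measured step, a number 14.4 percentage points higher from compound 2 to compound 3 (beyond the scatter), swaps other groups on another amine nitrogen, so it bears only loosely on this edit. No change beyond the scatter is expected, and the expected step is a number 2.9 percentage points higher from compound 1 to compound 4 (within the scatter) in this read-out. For compound 4 the estimate is 18% with an expected range of 7% to 38% in this read-out.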

Compound 4, percent of the compound remaining: 18.8%
Compound 4: the middle estimate sits 0.8 percentage points below what was measured; the measured number falls inside the stated range.
By their numbers in this assay, from the lowest: compounds 1 and 4 (each within the scatter of the next); then compound 2; then compound 3.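

In this assay, going from 4-isopropylpiperazin-1-yl to 4-ethylpiperazin-1-yl gives a number 3.7 percentage points higher from compound 1 to compound 4 (within the scatter) in this read-out. This is the first look at this place, and removing one methyl here leaves the number within the scatter, with both compounds still the two lowest shown. No measurement at hand explains this result.

Going by these compounds, what remains open is whether a different group at this place, such as a longer chain like butyl or an acetyl group, would move the number beyond the scatter.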